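This account rests on a few compounds, and the source may have more. Where it says the series, first, only, none or still open, it means among the compounds named here.

Measured compounds:
compound 1 `COc1ccc2c(=O)n(-c3ccc(Cl)cc3F)c(=O)oc2c1` — > 40000 nM
compound 2 `COc1ccc2c(=O)n(-c3ccc(F)cc3F)c(=O)oc2c1` — > 40000 nM
compound 3 `O=C(Nc1ccc(-c2ccc(Cl)cc2F)cc1F)c1ccccc1O` — 27200 nM

In an ADME assay on RAW264.7 cells (Mus musculus) for cytotoxicity, read by MTT assay, with a stated time of 24 h (on this read-out lower numbers stand for higher toxicity in this test and higher numbers for lower toxicity in this test), the result for compound 1 is a limit of the assay, > 40000 nM, and not a number. The result for compound 2 is likewise a limit, > 40000 nM. Among the measured compounds shown here, compound 3 is the only compound with a number in this assay, giving 27200 nM. The two other results share (the limit of > 40000 nM in this assay, at which 2 of the 3 values shown sit).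

Between compound 2 and compound 1 the change is chloro in place of fluoro on an aromatic carbon. The step that the two limits leave unreadable from compound 2 to compound 1 therefore carries no readable size. How the core of compound 3 differs from the core of compound 2 is not broken down here.

Compound 4 `O=C(Nc1ccc(-c2ccc(Cl)cc2Cl)cc1F)c1ccccc1O` has not yet been measured in this assay. It differs from compound 3 by chloro in place of fluoro on an aromatic carbon. The surroundings of the place are not the same as in the measured pair: in compound 4 the entering chloro sits ortho to a large group and meta to a chloro group, whereas in compound 1 it sits meta to a fluoro group and para to a large group. The two are the same kind of change, not the same change.

The expected step is a 1.1-fold lower number from compound 3 to compound 4 (0.04 log units; within the scatter), set beside a step that the two limits leave unreadable from compound 2 to compound 1, which gives no size to carry over. For the measured compounds named here, that expectation rests on compound 3 giving 27200 nM, the only number in the set. Compound 4 is estimated at 25000 nM, between 12000 nM and 50000 nM, with a real chance that only a limit is returned.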

Compound 4, half-maximal cytotoxic concentration: 29800 nM
The estimate for compound 4 lay 1.2-fold (0.08 log units) below the measured number, within the range that was stated.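

Notes on the halogen swap: in this assay, chloro in place of fluoro on an aromatic carbon, read here as 4-chloro-2-fluorophenyl to 2,4-dichlorophenyl, gives a 1.1-fold higher number from compound 3 to compound 4 (0.04 log units; within the scatter), so on this core the change leaves the read-out within the usual scatter. The same kind of change on the other core, from compound 2 to compound 1, cannot be read, as both results there are limits of the assay and not numbers: the limit of > 40000 nM in this assay, at which 2 of the 4 values shown sit.

The series therefore offers one readable step on one core, which shows that the swap is tolerated in that single setting but gives no evidence that the result carries over to the core of compound 1, where the place of the entering chloro also has different surroundings.

As far as these compounds go, it remains open how a group of another kind, such as an amine or a carboxylic acid, would read in this assay on the aromatic carbon that carries the fluoro in compound 3. Also open, from the compounds shown here alone, is whether any substituent on the core of compound 2 would return a number rather than a limit, which a readable comparison between the two cores would need.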